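This account rests on a few compounds, and the source may have more. Where it says the series, first, only, none or still open, it means among the compounds named here.

Measured compounds:
compound 1 `O=C(CSc1nc(Nc2ccccc2)c2ccccc2n1)Nc1cccc(Cl)c1` — 8460 nM
compound 2 `O=C(CSc1nc(Nc2ccccc2)c2ccccc2n1)Nc1ccc(Br)cc1` — 10600 nM
compound 3 `C=CC(=O)Nc1cccc(NC(=O)CSc2nc(Nc3cccc([N+](=O)[O-])c3)c3ccccc3n2)c1` — 22600 nM

In a functional assay on NCI-H1975 cells (Homo sapiens) for inhibition, read by MTT assay, with a stated time of 72 h (on this read-out higher numbers stand for weaker inhibition and lower numbers for stronger inhibition), compound 3 gives the highest number of the three, so it is the weakest inhibitor shown. Compound 4 `C=CC(=O)Nc1cccc(NC(=O)CSc2nc(Nc3ccc(CC)cc3)c3ccccc3n2)c1` differs from compound 3 in one place: 4-ethylphenyl in place of 3-nitrophenyl on a nitrogen on an aromatic ring. Going by the values given here, the only measured step, a 1.3-fold higher number from compound 1 to compound 2 (0.10 log units; within the scatter), changes a group on an amide-type nitrogen, not on the nitrogen where compound 4 differs, so no measured step bears directly on this change. Compounds 1 and 2, which carry a plain phenyl on that nitrogen, give lower numbers than compound 3, but they also differ elsewhere. With little to go on, the expected step of a 1.5-fold lower number from compound 3 to compound 4 (0.18 log units; within the scatter) is small and uncertain. Compound 4 is estimated at 15000 nM, ranging from 5000 nM to 45000 nM.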

Compound 4, half-maximal inhibitory concentration: 8270 nM
Compound 4: the middle estimate sits 1.8-fold (0.26 log units) above what was measured; low and high end bracket the measured number.
By their numbers in this assay, from the lowest: compounds 4, 1 and 2 (each within the scatter of the next); then compound 3.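

In this assay, the group on the nitrogen on an aromatic ring proves able to shift the number, with 4-ethylphenyl in place of 3-nitrophenyl giving a 2.7-fold lower number from compound 3 to compound 4 (0.44 log units; beyond the scatter). Going by these compounds alone, the earlier step changed only a group on an amide-type nitrogen, so this is the first measured change at this position. Nothing measured here explains the difference. The compounds shown leave open whether the step comes from gaining the ethyl group, losing the nitro group, or the different placement of each on the ring. On these data alone, how a longer chain such as propyl, or an amine, would read in place of the ethyl also remains open.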